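The source may report more compounds than this note shows. Statements on the series, on what has been measured and on what is new or still open speak of the compounds shown alone.

In this assay, an assay on isolated protein for agonist activity at Bile acid receptor (Homo sapiens), read by AlphaScreen, with a stated time of 30 min (on this read-out higher numbers stand for an effect only at larger amounts of compound and lower numbers for an effect already at smaller amounts), the measured compounds stand as follows: compound 1 `COC(=O)c1cccc(-c2ccc([C@H]3S[C@@H](C)C(=O)Nc4c3c(C)nn4-c3ccccc3C)cc2)c1` gives "not active" (no number reported); compound 2 `Cc1ccc(-n2nc(C)c3c2NC(=O)[C@H](C)S[C@@H]3c2ccc(Oc3ccccc3)cc2)cc1` gives 3400 nM; compound 3 `Cc1cccc(-n2nc(C)c3c2NC(=O)[C@H](C)S[C@@H]3c2ccc(Oc3ccccc3)cc2)c1` gives 2400 nM.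

Compound 1 therefore has no single number to stand on; in this assay it was reported only as "not active" (no number reported). Compound 4 `Cc1ccccc1-n1nc(C)c2c1NC(=O)[C@H](C)S[C@@H]2c1ccc(-c2cc3ccccc3o2)cc1` is built from compound 1 by one exchange: 1-benzofuran-2-yl in place of 3-(methoxycarbonyl)phenyl on an aromatic carbon. Among the measured compounds shown here, the only measured step, a 1.4-fold lower number from compound 2 to compound 3 (0.15 log units; within the scatter), touches a different group on a different atom, so it does not bear on this exchange. For the measured compounds named here, with no step for the change and no number for compound 1, neither direction nor size can be read from these data; only compounds 2 and 3 show that the shared core can give a number at all. Compound 4 is estimated at 3000 nM, expected between 500 nM and 20000 nM.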

Compound 4, half-maximal effective concentration: 1500 nM
Beside the measured number, compound 4's estimate is 2.0-fold (0.30 log units) above it, within the range that was stated.
By their numbers in this assay, from the lowest: compounds 4, 3 and 2 (each within the scatter of the next, the first and the last beyond it).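

In this assay compound 1 gives "not active" (no number reported) and so no step to compound 4 can be read, and nothing at hand explains the result. Still open, from the compounds shown here alone, is how much 1-benzofuran-2-yl in place of 3-(methoxycarbonyl)phenyl shifts the number.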